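This account rests on a few compounds, and the source may have more. Where it says the series, first, only, none or still open, it means among the compounds named here.

Of the compounds shown here, three have so far been measured in a functional assay on the whole organism (artery, strain albino) with Rattus norvegicus as the target, with a stated time of 120 min, at a dose of 10 mg/kg by the oral route; a lower number here means less inhibition, a higher number more inhibition at the dose given (going by the name of the read-out). Compound 1 `CC1=C(C(=O)Nc2ccc(F)cc2)C(c2ccc([N+](=O)[O-])cc2)N=C(SCc2ccccc2Cl)N1` gives 8.8% in this assay. Compound 2 `CC1=C(C(=O)Nc2ccc(F)cc2)C(c2ccc([N+](=O)[O-])cc2)N=C(SCc2cccc(Cl)c2)N1` carries 3-chlorophenyl in place of 2-chlorophenyl on a saturated chain carbon bound to a sulfur and gives 9.8% in this assay; the step between them is a number 1 percentage points higher from compound 1 to compound 2 (within the scatter). Compound 3 `COc1ccc(C2N=C(SCc3ccccc3Cl)NC(C)=C2C(=O)Nc2ccc(Br)cc2)cc1` rests on a different core; the difference between the core of compound 3 and the core of compound 1 is not broken down here. In this assay compound 3 gives 8.2%, and its gaps to compound 1 and to compound 2 both fall within the scatter, so no order among the three can be read from the numbers.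

Compound 4 `COc1ccc(C2N=C(SCc3cccc(Cl)c3)NC(C)=C2C(=O)Nc2ccc(Br)cc2)cc1` has not yet been measured in this assay. It differs from compound 3 by 3-chlorophenyl in place of 2-chlorophenyl on a saturated chain carbon bound to a sulfur. This is the same change as the one made from compound 1 to compound 2, at the same place, and it occurs twice in all among the compounds shown, once measured and once not.

The expectation for compound 4 in this assay rests on compound 3 and its value 8.2%, moved by a step of about the size of a number 1 percentage points higher from compound 1 to compound 2 (within the scatter). The step expected is a number 1 percentage points higher from compound 3 to compound 4 (within the scatter), which stays within the scatter. Compound 4 is expected to give 9.2%. The lower end expected for compound 4 is 3%. The upper end expected for compound 4 is 16%; the range is kept wide because a single measured instance of the change, a number 1 percentage points higher from compound 1 to compound 2 (within the scatter), gives little weight.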

Compound 4, a percentage reported as inhibition, in the whole organism at one dose (the size of the read-out at that dose, not a potency): 21.1%
Beside the measured number, compound 4's estimate is 11.9 percentage points below it; the whole stated range lies below it.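

In this assay, 3-chlorophenyl in place of 2-chlorophenyl on a saturated chain carbon bound to a sulfur, now placed on the core of compound 3, gives a step that is a number 12.9 percentage points higher from compound 3 to compound 4 (beyond the scatter). Set beside the earlier instance of the same change, this step cannot be told apart from it: the same change on two cores in this assay, a number 1 percentage points higher (within the scatter) from compound 1 to compound 2 and a number 12.9 percentage points higher (beyond the scatter) from compound 3 to compound 4, 11.9 percentage points apart, within the scatter of two such steps The series therefore shows the change on two cores, with a clear step on only one of them, but it does not show that the core decides the size of the step, nor that a step of either size carries over to a further core.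

Going by these compounds alone, with only two instances of the change, and with the difference between the core of compound 1 and the core of compound 3 not broken down, it remains open which part of the core, if any, goes with the size of the step. Also open, on these data alone, is how the series would read in this assay with an amine, a carboxylic acid or a longer chain in place of the 3-chlorobenzyl group on the sulfur.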